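The compounds below may be only part of what the source reports. "The series", "measured", "known", "first", "only" and "open" are said of these compounds alone.

Of the compounds shown here, two have so far been measured in a functional assay on PC-3 cells (Homo sapiens) for antiproliferative activity, read by MTT assay, tested at 5 uM; a lower number here means a weaker effect, a higher number a stronger effect of the compound at the concentration tested. Going by the values given here, compound 1 `COc1cc(C2=NN(C(C)=O)C(c3ccccc3C(F)(F)F)O2)cc(OC)c1OC` gives 15.2% in this assay, the lower of the two numbers; compound 2 `COc1cc(C(=O)N/N=C/c2ccc(F)cc2)cc(OC)c1OC` gives 82.8%, a number higher by more than the usual scatter, though the two are built differently and no single-change step connects them. Compound 3 `COc1cc(C2=NN(C(C)=O)C(c3cccc(F)c3)O2)cc(OC)c1OC` has not yet been measured in this assay. It differs from compound 1 in one place: 3-fluorophenyl in place of 2-(trifluoromethyl)phenyl on a saturated ring carbon. Among the compounds with values here, no measured pair shows this change, so the expected step of a number 9.8 percentage points higher from compound 1 to compound 3 (within the scatter) is taken to be small and upward, of a size near the scatter. On that basis compound 3 is expected to give about 25%, with a range from 5% to 55%.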

Compound 3, a percentage reported as inhibition, at one concentration (the size of the read-out at that concentration, not a potency): 43.5%
Compound 3: the middle estimate sits 18.5 percentage points below what was measured, within the range that was stated.
By their numbers in this assay, from the lowest: compound 1; then compound 3; then compound 2.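

Going by these compounds alone, the group on the saturated ring carbon can change the result in this assay by more than the scatter: 3-fluorophenyl in place of 2-(trifluoromethyl)phenyl gives a number 28.3 percentage points higher from compound 1 to compound 3 (beyond the scatter) and is the only single-place change with a readable step here. Compound 2 could not show this, since no single change connects it to the other compounds. Nothing measured here accounts for the step.

The compounds shown leave open whether the gain comes from the trifluoromethyl group leaving, the fluorine entering, or where each sits on the phenyl ring. They also leave open how an amine or a carboxylic acid would read at this place.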